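The source may hold more compounds than are shown below. What is called first, only, known or untested is meant among the compounds shown, and "the series" means these compounds.

Measured compounds:
compound 1 `COc1ccc(-c2cc(C(=O)/C=C/c3ccccc3)nc3cc(-c4ccccc4)nn23)cc1OC`; in an ADME assay on HEK293 cells (Homo sapiens) for antiproliferative activity, read by MTT assay, with a stated time of 24 h (a higher number here means a weaker inhibitor, a lower number a stronger inhibitor), compound 1 gives 64100 nM
compound 2 `COc1cc(-c2cc(C(=O)/C=C/c3ccccc3)nc3cc(-c4ccccc4)nn23)cc(OC)c1OC`; in this assay compound 2 gives 44800 nM
compound 3 `COc1ccc(-c2cc(/C=C/C(=O)c3ccc(C)cc3)nc3cc(-c4ccccc4)nn23)cc1OC`; in this assay compound 3 gives 62600 nM

Compound 2 is compound 1 with methoxy in place of hydrogen on an aromatic carbon, and that change gives a 1.4-fold lower number from compound 1 to compound 2 (0.16 log units; within the scatter). Compound 3 carries a different core than compound 1: 2-((4-methylphenyl)carbonyl)ethenyl in place of (2-phenylethenyl)carbonyl on an aromatic carbon. The cores give a 1.0-fold lower number from compound 1 to compound 3 (0.01 log units; within the scatter), so all three numbers sit within the scatter of one another.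

Compound 4 `COc1cc(-c2cc(/C=C/C(=O)c3ccc(C)cc3)nc3cc(-c4ccccc4)nn23)cc(OC)c1OC` is compound 3 with methoxy in place of hydrogen on an aromatic carbon. The surroundings of the place are the same, word for word, as from compound 1 to compound 2, so this is the same change, made here on the core of compound 3. The step is expected to be a 1.4-fold lower number from compound 3 to compound 4 (0.13 log units; within the scatter), to be set beside a 1.4-fold lower number from compound 1 to compound 2 (0.16 log units; within the scatter); it rests on that earlier step and on the near-equal numbers of compound 1 and compound 3, and an essentially flat outcome is as likely as a small shift. For compound 4 in this assay the expected number is 46000 nM, estimated to fall between 25000 nM and 85000 nM.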

Compound 4, half-maximal inhibitory concentration: 50400 nM
Estimate against measurement, compound 4: 1.1-fold (0.04 log units) below; measured number inside the range.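

In this assay, the change from 3,4-dimethoxyphenyl to 3,4,5-trimethoxyphenyl gives a 1.2-fold lower number from compound 3 to compound 4 (0.09 log units; within the scatter), and no difference between the two cores can be seen for it: the same change on two cores in this assay, a 1.4-fold lower number (0.16 log units; within the scatter) from compound 1 to compound 2 and a 1.2-fold lower number (0.09 log units; within the scatter) from compound 3 to compound 4, 1.2-fold (0.06 log units) apart, within the scatter of two such steps

The exchange of (2-phenylethenyl)carbonyl for 2-((4-methylphenyl)carbonyl)ethenyl, now read on the trimethoxyphenyl compounds, gives a 1.1-fold higher number from compound 2 to compound 4 (0.05 log units; within the scatter), again with no difference from its earlier counterpart: the same change on two cores in this assay, a 1.0-fold lower number (0.01 log units; within the scatter) from compound 1 to compound 3 and a 1.1-fold higher number (0.05 log units; within the scatter) from compound 2 to compound 4, 1.2-fold (0.06 log units) apart, within the scatter of two such steps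

Every step here lies within the scatter, so the two changes carry across only in the sense that neither produces a step beyond the scatter on either core; this does not show that either change has an effect of its own, or that a larger effect would transfer.

On these data alone, whether any change with a step beyond the scatter transfers between these cores stays open. So does the behaviour of an amine or a carboxylic acid in place of the added methoxy on either core.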